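The compounds below may be only part of what the source reports. "The series", "measured", "known", "first", "only" and "open" are said of these compounds alone.

Measured compounds in a functional assay on PC-12 cells (Rattus norvegicus) for cytotoxicity, read by MTT assay, with stated times of 2 h and 24 h, tested at 1 uM; on this read-out lower numbers stand for a weaker effect and higher numbers for a stronger effect at the one concentration tested:
compound 1, `Cc1ccc(-n2nc(-c3ccc(C(F)(F)F)cc3O)nc2-c2ccccc2O)cc1`: 71.5%
compound 2, `Oc1cc(C(F)(F)F)ccc1-c1nc(-c2ccccc2O)n(-c2ccc(I)cc2)n1`: 70.1%
compound 3, `Oc1cc(C(F)(F)F)ccc1-c1nc(-c2ccccc2O)n(-c2ccc(OC(F)(F)F)cc2)n1`: 65.5%

Compound 3 stands at the low end of these three numbers, yet the steps of a number 6 percentage points lower from compound 1 to compound 3 (within the scatter) and a number 4.6 percentage points lower from compound 2 to compound 3 (within the scatter) both lie within the scatter, so the three compounds cannot be told apart in this assay. Compound 4, `COc1ccccc1-n1nc(-c2ccc(C(F)(F)F)cc2O)nc1-c1ccccc1O`, is not yet measured. It differs from compound 3 in one place: 2-methoxyphenyl in place of 4-(trifluoromethoxy)phenyl on an aromatic nitrogen. All three measured steps concern the same aromatic nitrogen: a number 1.4 percentage points lower from compound 1 to compound 2 (within the scatter), a number 6 percentage points lower from compound 1 to compound 3 (within the scatter) and a number 4.6 percentage points lower from compound 2 to compound 3 (within the scatter), none beyond the scatter. Going by the values given here, no measured step involves a 2-methoxyphenyl group, so their bearing is only indirect; still, since every exchange at this position left this assay unchanged beyond the scatter, no step beyond the scatter is expected for compound 4 either, a number 2.5 percentage points higher from compound 3 to compound 4 (within the scatter). Compound 4 is estimated at 68%, with a range from 55% to 80%.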

Compound 4, a percentage reported as activity, at one concentration (the size of the read-out at that concentration, not a potency): 70.7%
Beside the measured number, compound 4's estimate is 2.7 percentage points below it, and the stated range covers the measured number.
By their numbers in this assay, from the lowest: compounds 3, 2, 4 and 1 (each within the scatter of the next).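

In this assay, going by these compounds alone, the 2-methoxyphenyl group is the first on this aromatic nitrogen that does not carry its substituent at the 4-position of the phenyl ring, and a number 5.2 percentage points higher from compound 3 to compound 4 (within the scatter) and a number 0.6 percentage points higher from compound 2 to compound 4 (within the scatter) and a number 0.8 percentage points lower from compound 1 to compound 4 (within the scatter) all stay within the scatter. The read-out therefore separates neither this change of substituent place nor the earlier exchanges of substituent at this nitrogen. No measurement offered here accounts for this.

The compounds shown leave open whether a phenyl group bearing an amine or a carboxylic acid on this nitrogen, or a longer alkyl chain in place of the phenyl ring, would move the read-out beyond the scatter. From the compounds shown here alone, the 2-hydroxyphenyl and 2-hydroxy-4-(trifluoromethyl)phenyl groups are the same in all four compounds, so their part remains untested.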